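Pyrazole substituent variation in the amide series

The source may report more compounds than this note shows. Statements on the series, on what has been measured and on what is new or still open speak of the compounds shown alone.

Among the compounds with values here, the two measured members share one core. Compound 1 `CNC(=O)N1CCCc2ccc(NC(=O)c3ccc(-c4cnn(C)c4)cc3)cc21` in a functional assay on MV4-11 cells (Homo sapiens) for antiproliferative activity, with a stated time of 6 days, tested at 1.56 uM (a higher number here means a stronger effect of the compound at the concentration tested, a lower number a weaker effect), gives 77.4%. Within the data shown here, compound 2 `CNC(=O)N1CCCc2ccc(NC(=O)c3ccc(-c4ccn(C(C)=O)n4)cc3)cc21` in this assay gives 35.8%, the lowest of the two numbers; the only neighbour, compound 1, is higher by a margin beyond the scatter, the step being a number 41.6 percentage points lower from compound 1 to compound 2 (beyond the scatter). Compound 3 `CNC(=O)N1CCCc2ccc(NC(=O)c3ccc(-c4cnn(S(C)(=O)=O)c4)cc3)cc21` is unmeasured and differs from compound 2 by 1-(methylsulfonyl)-1H-pyrazol-4-yl in place of 1-acetyl-1H-pyrazol-3-yl on an aromatic carbon. Among the measured compounds shown here, the one measured step bears on this only in part: it changed both the ring attachment point and the nitrogen substituent together, and was large. Compound 3 restores the 4-yl attachment of compound 1 while keeping a nitrogen substituent of the acyl kind seen in compound 2, so a partial recovery is expected, a rise of a number 19.2 percentage points higher from compound 2 to compound 3 (beyond the scatter) in this assay. Compound 3 is therefore estimated at 55%, with a range from 25% to 80%.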

Compound 3, a percentage reported as inhibition, at one concentration (the size of the read-out at that concentration, not a potency): 4.5%
Compound 3: middle estimate off by 50.5 percentage points, on the high side; the measured number lies below the stated range.
By their numbers in this assay, from the lowest: compound 3; then compound 2; then compound 1.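

Within the data shown here, compound 3 gives the first reading of the nitrogen substituent alone: with the 1H-pyrazol-4-yl attachment of compound 1 held, methylsulfonyl in place of methyl on the aromatic nitrogen gives a number 72.9 percentage points lower from compound 1 to compound 3 (beyond the scatter) in this assay. The 4-yl attachment alone therefore does not secure a strong read-out at the concentration tested, since the step gives a number 31.3 percentage points lower from compound 2 to compound 3 (beyond the scatter), although that step changes the attachment point and the nitrogen substituent together and cannot separate them. No measurement on hand accounts for either drop.

From the compounds shown here alone, the separate contribution of the attachment point remains open, and 1-acetyl-1H-pyrazol-4-yl and 1-methyl-1H-pyrazol-3-yl would each isolate it. Also open, going by these compounds, is how far the read-out of the methyl compound extends to an ethyl or 2-hydroxyethyl group on that nitrogen.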